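The source may hold more compounds than are shown below. What is called first, only, known or untested is meant among the compounds shown, and "the series" means these compounds.

The measured compounds, in a functional assay on HL-60 cells (Homo sapiens) for antiproliferative activity, read by XTT assay, with a stated time of 72 h; on this read-out lower numbers stand for stronger inhibition and higher numbers for weaker inhibition:

Compound 1 `COc1ncnc2c1c(I)cn2[C@@H]1O[C@H](CO)[C@@H](O)[C@H]1O` gives 2300 nM.
Compound 2 `C#Cc1cn([C@@H]2O[C@H](CO)[C@@H](O)[C@H]2O)c2ncnc(OC)c12` gives 190 nM.
Compound 3 `C#Cc1cn([C@@H]2O[C@H](CO)[C@@H](O)[C@H]2O)c2nc(N)nc(OC)c12` gives only a limit of the assay, > 20000 nM.

Compound 2 stands lowest of the two numbers recorded; its nearest neighbour is compound 1, and the step of a 12-fold lower number from compound 1 to compound 2 (1.08 log units; beyond the scatter) lies beyond the scatter. The other measured step, an at least 100-fold higher number from compound 2 to compound 3 (2.02 log units; beyond the scatter), ends at the limit of > 20000 nM in this assay, at which 1 of the 3 values shown sits, so only its direction and a lower bound on its size are known.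

Compound 4 `C#Cc1cn([C@@H]2O[C@H](CO)[C@@H](O)[C@H]2O)c2ncnc(SC)c12` differs from compound 2 by methylsulfanyl in place of methoxy on an aromatic carbon. Neither measured step touches the methoxy: one exchanges iodo for ethynyl, the other adds an amino group, and both leave the methoxy in place. Going by the values given here, the data therefore hold no step that bears directly on this exchange, and the expectation rests on the position being a small group swapped for another small group at the same place.

Compound 4 is accordingly expected to give about 150 nM, with a range of 40 nM to 600 nM. The implied step a 1.3-fold lower number from compound 2 to compound 4 (0.10 log units; within the scatter) is expected to sit within the scatter, in neither direction with confidence.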

Compound 4, half-maximal inhibitory concentration: 50 nM
For compound 4 the middle estimate is 3.0-fold (0.48 log units) above the measured one, and the stated range covers the measured number.
By their numbers in this assay, from the lowest: compound 4; then compound 2; then compound 1. At a limit, above all of these: compound 3.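

Going by these compounds alone, compound 2 and compound 4 give the first measured step at this aromatic carbon, where sulfur takes the place of oxygen in the substituent: a 3.8-fold lower number from compound 2 to compound 4 (0.58 log units; beyond the scatter). The earlier steps shown here left the methoxy in place, so only now does this assay show that this position responds to an exchange between methoxy and methylsulfanyl, with the ethynyl group and the rest of the molecule unchanged. Nothing measured here accounts for the direction or the size of this step.

Going by these compounds, it remains open how a longer chain such as ethylsulfanyl, or an amine, would read on this same carbon. On these data alone, it is also open whether the lower number seen with methylsulfanyl would persist alongside the amino group that compound 3 carries.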